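Swapping the ring halogen for a methyl group

The source may hold more compounds than are shown below. What is called first, only, known or untested is meant among the compounds shown, and "the series" means these compounds.

For the measured compounds named here, compound 3, `Cn1nnnc1SCC(=O)N/N=C/c1ccccc1Br`, gives the lowest of the two numbers known in an ADME assay on NIH3T3 cells (Mus musculus) for cytotoxicity, read by XTT assay, with a stated time of 24 h (on this read-out higher numbers stand for weaker inhibition and lower numbers for stronger inhibition), 20000 nM. Compound 1, `Cn1nnnc1SCC(=O)N/N=C/c1ccccc1F`, gives 2000000 nM in this assay. Compound 2, `Cn1nnnc1SCC(=O)N/N=C/c1ccccc1Cl`, reaches only a limit of the assay, > 10000000 nM, consistent with the limit of > 10000000 nM in this assay, at which 1 of the 3 values shown sits. Compound 4, `Cc1ccccc1/C=N/NC(=O)CSc1nnnn1C`, differs from compound 3 by methyl in place of bromo on an aromatic carbon. The measured steps at this position were large: a 100-fold lower number from compound 1 to compound 3 (2.00 log units; beyond the scatter) and an at least 500-fold lower number from compound 2 to compound 3 (2.69 log units; beyond the scatter), while an at least 5.0-fold higher number from compound 1 to compound 2 (0.69 log units; beyond the scatter) was smaller. None of these replaces bromo with methyl, so the direction is uncertain, but the size of those steps makes a change beyond the scatter, most likely toward weaker inhibition, the expectation. Compound 4 is therefore estimated at 1000000 nM, within 50000 nM to 10000000 nM. The expected step is a 50-fold higher number from compound 3 to compound 4 (1.70 log units; beyond the scatter).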

Compound 4, half-maximal inhibitory concentration: 6320000 nM
Compound 4: middle estimate off by 6.3-fold (0.80 log units), on the low side, within the range that was stated.
By their numbers in this assay, from the lowest: compound 3; then compound 1; then compound 4. At a limit, above all of these: compound 2.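

In this assay, methyl does not keep the low number seen with bromo: a 320-fold higher number from compound 3 to compound 4 (2.50 log units; beyond the scatter). Compound 3 thus stands apart among the four, as methyl also sits clear of fluoro, with a 3.2-fold higher number from compound 1 to compound 4 (0.50 log units; beyond the scatter), while the comparison with chloro gives an at least 1.5-fold lower number from compound 2 to compound 4 (0.19 log units; that floor lies within the scatter) and so sets no firm order. Compound 2 stands at a limit, not at a number: the limit of > 10000000 nM in this assay, at which 1 of the 4 values shown sits. As far as these compounds go, whether the low number is peculiar to bromo stays open. Iodo, methoxy or an amine on the same aromatic carbon would test this.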